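A few compounds are considered here, and "the series" means these few. Any claim that something is new, unique, unknown or untested is made for them only; others in the source may bear on it.

Compound 3 `CN(C(=O)NC(=O)c1cccc(C(F)(F)F)c1)c1nc(C(F)(F)F)c(C(=O)N/N=C/c2ccccc2C(F)(F)F)s1` is measured in a functional assay on HepG2 cells (Homo sapiens) for inhibition, read by MTT assay, with a stated time of 72 h (on this read-out lower numbers stand for stronger inhibition and higher numbers for weaker inhibition), at 10.4 ug/mL. Compound 2 `CN(C(=O)NC(=O)c1cccc(C(F)(F)F)c1)c1nc(C(F)(F)F)c(C(=O)N/N=C/c2ccc(C(F)(F)F)cc2)s1` gives 7.71 ug/mL, and compound 1 `CN(C(=O)NC(=O)c1ccc(F)c(F)c1)c1nc(C(F)(F)F)c(C(=O)N/N=C/c2ccc(C(F)(F)F)cc2)s1` gives 6.26 ug/mL. The gap between these neighbours and compound 3 is no wider than the scatter, as the step of a 1.3-fold higher number from compound 2 to compound 3 (0.13 log units; within the scatter) shows. Compound 4 `CN(C(=O)NC(=O)c1ccc(F)c(F)c1)c1nc(C(F)(F)F)c(C(=O)N/N=C/c2ccccc2C(F)(F)F)s1` carries the change (3,4-difluorophenyl in place of 3-(trifluoromethyl)phenyl on a carbonyl carbon). The same swap, run the other way round, is already known from a 1.2-fold higher number from compound 1 to compound 2 (0.09 log units; within the scatter), a shift that stayed within the scatter. In this assay a step of similar small size is therefore expected, a 1.2-fold lower number from compound 3 to compound 4 (0.09 log units; within the scatter), pointing toward a slightly lower number but not beyond the scatter. Compound 4 is accordingly estimated at 8.5 ug/mL, with a range from 4.3 ug/mL to 17 ug/mL.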

Compound 4, half-maximal inhibitory concentration: 10.4 ug/mL
Beside the measured number, compound 4's estimate is 1.2-fold (0.09 log units) below it; the measured number falls inside the stated range.
By their numbers in this assay, from the lowest: compounds 1, 2, 3 and 4 (each within the scatter of the next).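

In this assay, the change to 3,4-difluorophenyl from 3-(trifluoromethyl)phenyl on a carbonyl carbon, now seen alongside 2-(trifluoromethyl)phenyl, gives no change at the digits printed from compound 3 to compound 4 (within the scatter), so the small size of this step holds on a second core: the same change on two cores in this assay, a 1.2-fold higher number (0.09 log units; within the scatter) from compound 1 to compound 2 and no change at the digits printed (within the scatter) from compound 4 to compound 3, 1.2-fold (0.09 log units) apart, within the scatter of two such steps Likewise, 2-(trifluoromethyl)phenyl in place of 4-(trifluoromethyl)phenyl on a carbon with a double bond to nitrogen, now seen with 3,4-difluorophenyl, gives a 1.7-fold higher number from compound 1 to compound 4 (0.22 log units; within the scatter), and this step also repeats on a second core: the same change on two cores in this assay, a 1.3-fold higher number (0.13 log units; within the scatter) from compound 2 to compound 3 and a 1.7-fold higher number (0.22 log units; within the scatter) from compound 1 to compound 4, 1.2-fold (0.09 log units) apart, within the scatter of two such steps The compounds shown carry only fluorine or trifluoromethyl on these phenyl groups. Going by these compounds, whether an amine or a carboxylic acid on either phenyl group would move the number beyond the scatter remains open.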